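Removing a Fluoro Group on Two Related Cores

This account rests on a few compounds, and the source may have more. Where it says the series, first, only, none or still open, it means among the compounds named here.

Compound 1 `N#C/C(=C\c1c[nH]c2cc(F)ccc12)C(=O)c1c[nH]c2cc(F)ccc12`: in a functional assay on PC-3 cells (Homo sapiens) for cytotoxicity, read by WST assay, with a stated time of 48 h (a higher number here means a weaker inhibitor, a lower number a stronger inhibitor), compound 1 gives only the limit > 50000 nM, not a number.
Compound 2 `N#C/C(=C\c1c[nH]c2cc(F)ccc12)C(=O)c1c[nH]c2ccccc12`: in this assay compound 2 gives only the limit > 50000 nM, not a number.
Compound 3 `COc1ccc(Cn2cc(/C=C(\C#N)C(=O)c3c[nH]c4cc(F)ccc34)c3ccccc32)cc1`: in this assay compound 3 gives only the limit > 50000 nM, not a number.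

Compounds 1 and 2 share one core and differ in a single place: hydrogen in place of fluoro on an aromatic carbon. For the measured compounds named here, because both values are limits, the step that the two limits leave unreadable from compound 1 to compound 2 cannot be read; the data say only that neither compound reaches a measurable inhibition here. The difference between the core of compound 1 and the core of compound 3 is not broken down here.

Compound 4 `COc1ccc(Cn2cc(/C=C(\C#N)C(=O)c3c[nH]c4ccccc34)c3ccccc32)cc1` has not yet been measured in this assay. It differs from compound 3 by hydrogen in place of fluoro on an aromatic carbon. This is the same change as that from compound 1 to compound 2, made at a place that is described in the same words in both pairs.

The step from compound 3 to compound 4 is expected to be a step that the limit leaves unreadable from compound 3 to compound 4, and this expectation rests on the fact that the same change left compound 1 and compound 2 both at a limit, because of the limit of > 50000 nM in this assay, at which 3 of the 3 values shown sit. On that basis compound 4 is expected to give about 80000 nM in this assay, most likely again as a limit rather than a number, with a range estimated from 30000 nM to 300000 nM.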

Compound 4, half-maximal inhibitory concentration: > 50000 nM
Compound 4 ended at the assay's limit (the forecaster's own chance of this, stated with the estimate: 85%); the middle value is on the limit's open side.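

In this assay compound 4 gives > 50000 nM, which is a limit of the assay and not a number. Compound 3 also stands at a limit, so no size can be read for the change from compound 3 to compound 4. The compounds shown leave open whether going from 6-fluoro-1H-indol-3-yl to 1H-indol-3-yl alters cytotoxicity at all, and which structures would give a measurable value in this assay.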